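A few compounds are considered here, and "the series" means these few. Any claim that something is new, unique, unknown or untested is made for them only; others in the source may bear on it.

In a functional assay on COLO 205 cells (Homo sapiens) for antiproliferative activity, read by MTT assay, with a stated time of 68 h (on this read-out lower numbers stand for stronger inhibition and higher numbers for weaker inhibition), compound 2 `O=S(=O)(Nc1ccc(F)c(C#Cc2cnc3[nH]ncc3c2)c1F)c1cccnc1` gives 445 nM, the lowest of the two numbers shown. Compound 1 `O=S(=O)(Nc1ccc(F)c(C#Cc2cnc3[nH]ncc3c2)c1F)c1ccccc1F` gives 534 nM, and the step of a 1.2-fold lower number from compound 1 to compound 2 (0.08 log units; within the scatter) lies within the scatter. For compound 3 `O=S(=O)(Nc1ccc(F)c(C#Cc2ccc3[nH]ncc3c2)c1F)c1cccnc1` only a limit is recorded, > 10000 nM. The step of an at least 22-fold higher number from compound 2 to compound 3 (1.35 log units; beyond the scatter) is large. Compound 4 `O=S(=O)(Nc1ccc(F)c(C#Cc2cnc3[nH]nc(-c4ccccc4)c3c2)c1F)c1cccnc1` differs from compound 2 by phenyl in place of hydrogen on an aromatic carbon. Among the measured compounds shown here, neither measured step touches this position: one alters the group on the sulfonyl sulfur, the other exchanges the fused ring system carried by the triple-bonded carbon, so no measured step bears directly on the added phenyl. Without such guidance only a step of modest size, if any, is expected for compound 4, a 1.8-fold higher number from compound 2 to compound 4 (0.25 log units; within the scatter). Compound 4 is therefore estimated at 800 nM, between 200 nM and 4000 nM.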

Compound 4, half-maximal inhibitory concentration: 200 nM
Beside the measured number, compound 4's estimate is 4.0-fold (0.60 log units) above it; measured number inside the range.
By their numbers in this assay, from the lowest: compound 4; then compounds 2 and 1 (each within the scatter of the next). At a limit, above all of these: compound 3.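

In this assay, phenyl in place of hydrogen on this aromatic carbon of the five-membered ring gives a 2.2-fold lower number from compound 2 to compound 4 (0.35 log units; beyond the scatter), a modest gain in strength. Among the compounds shown here, the earlier steps changed only the group on the sulfonyl sulfur and the fused ring system, so this is the first sign that this carbon can carry a phenyl ring without loss of activity. Nothing shown explains why the number falls with this change. Going by these compounds, whether methyl, an amine or a carboxylic acid at this carbon would do as well remains open, as does whether the gain holds with the 2-fluorophenyl group of compound 1.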